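Hydroxypyrrolidine for hydroxypiperidine on the sulfonyl: stability notes

The compounds below may be only part of what the source reports. "The series", "measured", "known", "first", "only" and "open" are said of these compounds alone.

Values in an ADME assay on microsomes from liver (Rattus norvegicus) for metabolic stability, read by LC-MS, using NADPH, with a stated time of 30 min, tested at 0.1 uM (a higher number here means that more of the compound is left, a lower number that less of the compound is left), for the three measured compounds:

compound 1 `O=S(=O)(c1cccc(-c2ccc3nccc(-c4ccncc4)c3n2)c1)N1CCC(O)CC1`: 11%
compound 2 `O=S(=O)(NCc1ccccc1)c1cccc(Nc2ccc3nccc(-c4ccncc4)c3n2)c1`: 6%
compound 3 `O=S(=O)(CCO)c1cccc(-c2ccc3nccc(-c4ccncc4)c3n2)c1`: 59%

Compound 1 stands second highest of the three numbers. Among the measured compounds shown here, compound 2 lies within the scatter of compound 1, so nothing separates them; no single-point step is drawn between them, as the two structures differ in more than one place. Compound 3 is the furthest from compound 1, with a number 48 percentage points higher from compound 1 to compound 3 (beyond the scatter) from compound 1 to compound 3, a large step beyond the scatter.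

The next compound, compound 4 `O=S(=O)(c1cccc(-c2ccc3nccc(-c4ccncc4)c3n2)c1)N1CC[C@H](O)C1`, differs from compound 1 in one place: 3-hydroxypyrrolidin-1-yl in place of 4-hydroxypiperidin-1-yl on a sulfonyl sulfur

For the measured compounds named here, only the step from compound 1 to compound 3 touches the same position, and there a ring gave way to a chain, which does not match a change of ring size with the hydroxyl kept. Going by the values given here, that step was large, but no measured pair shows one ring of this kind against another. Among the compounds with values here, with no closer precedent, the expectation is for a step within the scatter, in no clear direction. Compound 4 is therefore expected to give about 15%, within 5% to 35%. The estimated step is a number 4 percentage points higher from compound 1 to compound 4 (within the scatter), within the scatter.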

Compound 4, percent of the compound remaining: 10%
For compound 4 the middle estimate is 5 percentage points above the measured one, and the stated range covers the measured number.
By their numbers in this assay, from the lowest: compounds 2, 4 and 1 (each within the scatter of the next); then compound 3.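

In this assay the size of the hydroxylated ring on the sulfonyl sulfur makes no readable difference: 3-hydroxypyrrolidin-1-yl in place of 4-hydroxypiperidin-1-yl stays within the scatter (a number 1 percentage points lower from compound 1 to compound 4 (within the scatter)). The open chain now stands apart from a second ring as well, with 3-hydroxypyrrolidin-1-yl in place of 2-hydroxyethyl giving a large step (a number 49 percentage points lower from compound 3 to compound 4 (beyond the scatter)), so the gap to compound 3 is not confined to the six-membered ring. Nothing available bears on the reason for this gap, which remains unexplained.

Open, from the compounds shown here alone, is whether the number for compound 3 depends on the hydroxyl or on the open chain, a question that an ethyl group or a longer chain such as 3-hydroxypropyl on the same sulfonyl sulfur would address. Also open, going by these compounds, is whether an open-chain amine on that sulfur, such as 2-hydroxyethylamino, follows the two rings or compound 3, and whether the opposite stereocentre of the 3-hydroxypyrrolidin-1-yl group matters.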